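Replacing a nitrile with a carboxymethylamino group in a series

A few compounds are considered here, and "the series" means these few. Any claim that something is new, unique, unknown or untested is made for them only; others in the source may bear on it.

Measured so far:
- Compound 1 `Cc1cc(-c2ccc3ccc(C(=O)c4ccc(F)c(O)c4)nc3c2)ccc1O`: 80%
- Compound 2 `N#Cc1ccc2ccc(C(=O)c3ccc(F)c(O)c3)nc2c1`: 56%
- Compound 3 `Oc1cc(Nc2cccc(-c3cccc(O)c3F)n2)ccc1F`: 82%

The read-out throughout is an assay for inhibition of 17-beta-hydroxysteroid dehydrogenase type 2 (Homo sapiens), read by HPLC, with a stated time of 10 min, tested at 1 uM; on this read-out lower numbers stand for less inhibition and higher numbers for more inhibition at the one concentration tested (going by the name of the read-out). Compound 2 stands lowest of the three numbers. Its nearest neighbour is compound 1, whose value lies beyond the scatter above it, and compound 3 lies further above still; compound 3 is built on a different core, so its value only shows where the highest number of the set sits.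

The unmeasured compound 4 `O=C(O)CNc1ccc2ccc(C(=O)c3ccc(F)c(O)c3)nc2c1` keeps the core of compound 2 and differs from it in one place: (carboxymethyl)amino in place of cyano on an aromatic carbon. Going by the values given here, the one measured step that touches this position is a number 24 percentage points lower from compound 1 to compound 2 (beyond the scatter), which shows that exchanging a large aromatic group there for the small cyano group lowered the read-out by a modest amount. That step shows a higher number with the 4-hydroxy-3-methylphenyl group than with the cyano group at this position, but the (carboxymethyl)amino group resembles neither the cyano nor the aromatic group, so the direction is uncertain. A small rise, or no change beyond the scatter, is therefore expected, giving an estimated step of a number 6 percentage points higher from compound 2 to compound 4 (within the scatter). For compound 4 in this assay the estimated value is 62%, with a range from 35% to 85%.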

Compound 4, a percentage reported as inhibition, at one concentration (the size of the read-out at that concentration, not a potency): 63%
The estimate for compound 4 lay 1 percentage points below the measured number; the range from low to high includes it.
By their numbers in this assay, from the lowest: compounds 2 and 4 (each within the scatter of the next); then compounds 1 and 3 (each within the scatter of the next).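

In this assay this position accepts a clear change of group without a shift beyond the scatter: (carboxymethyl)amino in place of cyano gives a number 7 percentage points higher from compound 2 to compound 4 (within the scatter), even though the entering group has more heavy atoms and carries hydrogen-bond donors, which cyano lacks. Earlier, the 4-hydroxy-3-methylphenyl group had been compared only with cyano, and the new compound adds a second, very different partner without a ring: a number 17 percentage points lower from compound 1 to compound 4 (beyond the scatter). So among these three compounds, the group with the ring stands apart from both groups without one, while those two cannot be told apart. Nothing given here explains these numbers.

The compounds shown leave open whether the carboxylic acid of the new group matters at all, which a plain amine or the methyl ester at the same aromatic carbon would help to test. They also leave open how a longer chain carrying the acid would read, and whether a simple phenyl ring would match the 4-hydroxy-3-methylphenyl group.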